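Chloro for methoxy on the acid-bearing core

This account rests on a few compounds, and the source may have more. Where it says the series, first, only, none or still open, it means among the compounds named here.

Compound 1 `O=C(O)c1c(O)cc(Cl)cc1C=Cc1ccc2ccccc2c1` is the starting point; in an ADME assay on HepG2 cells (Homo sapiens) for cytotoxicity, read by resazurin assay, with a stated time of 24 h (a higher number here means that more compound is tolerated, a lower number that less compound is tolerated), compound 1 gives 25000 nM. Compound 2 `COc1cc(O)c(C(=O)O)c(C=Cc2ccc3ccccc3c2)c1` carries methoxy in place of chloro on an aromatic carbon, and in this assay compound 2 gives 79000 nM, so a 3.2-fold higher number from compound 1 to compound 2 (0.50 log units; beyond the scatter). Compound 3 `COc1cc(C=Cc2ccc3ccccc3c2)c(C(=O)O)c(OC)c1` carries methyl in place of hydrogen on an oxygen on an aromatic ring. In this assay compound 3 gives > 100000 nM, which is a limit of the assay and not a number, namely (the limit of > 100000 nM in this assay, at which 1 of the 3 values shown sits). The step of an at least 1.2-fold higher number from compound 2 to compound 3 (0.10 log units; that floor lies within the scatter) is accordingly only a floor. Compound 3 thus stands at the upper edge of the numbers shown, without a number of its own.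

Compound 4 `COc1cc(Cl)cc(C=Cc2ccc3ccccc3c2)c1C(=O)O` differs from compound 3 by chloro in place of methoxy on an aromatic carbon, the exchange sitting meta to a methoxy group and para to a carboxy group. Within the data shown here, the one measured step that bears on it is the same exchange run the other way, a 3.2-fold higher number from compound 1 to compound 2 (0.50 log units; beyond the scatter), which lay beyond the scatter. Reversing it, a downward step of comparable size is expected, though the starting point is only a limit. For compound 4 in this assay the expected value is 40000 nM, between 15000 nM and 150000 nM. The expected change is an at least 2.5-fold lower number from compound 3 to compound 4 (0.39 log units; beyond the scatter).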

Compound 4, half-maximal cytotoxic concentration: 104000 nM
Beside the measured number, compound 4's estimate is 2.6-fold (0.41 log units) below it; the range from low to high includes it.
By their numbers in this assay, from the lowest: compound 1; then compounds 2 and 4 (each within the scatter of the next).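

Methyl in place of hydrogen on the oxygen now has a readable size on the chloro-bearing core in this assay, namely a 4.2-fold higher number from compound 1 to compound 4 (0.62 log units; beyond the scatter). The earlier step for this change gave only a floor, so the comparison between the two cores remains incomplete: the same change on two cores in this assay, an at least 1.2-fold higher number (0.10 log units; that floor lies within the scatter) from compound 2 to compound 3 and a 4.2-fold higher number (0.62 log units; beyond the scatter) from compound 1 to compound 4; the limit leaves it open whether they differ

The step from methoxy to chloro on the aromatic carbon para to a carboxy group cannot be read on this methylated core because compound 3 gives > 100000 nM, which is a limit of the assay and not a number: the limit of > 100000 nM in this assay, at which 1 of the 4 values shown sits.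

As far as these compounds go, it remains open whether chloro in place of methoxy changes the number at all when the oxygen carries methyl, and whether the methyl change is larger on one core than on the other. An amine or a nitrile on this aromatic carbon, or a longer chain in place of the methyl on the oxygen, would show whether the numbers seen with chloro and methoxy extend to other groups.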